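The source may hold more compounds than are shown below. What is called first, only, known or untested is meant among the compounds shown, and "the series" means these compounds.

Measured so far:

Compound 1 `COc1cc2nc(OC3CCN(C(=O)OC(C)(C)C)CC3)nc(Nc3ccc(S(C)(=O)=O)cc3F)c2cc1OC`. In a functional assay on HEK293 cells for agonist activity at Glucose-dependent insulinotropic receptor (Homo sapiens), read by cAMP accumulation, with a stated time of 60 min (on this read-out higher numbers stand for an effect only at larger amounts of compound and lower numbers for an effect already at smaller amounts), compound 1 gives > 10000 nM, which is a limit of the assay and not a number.

Compound 2 `COc1cc2nc(N3CCC4CCC(C3)N4Cc3ccccc3)nc(Nc3ccc(S(C)(=O)=O)cc3F)c2cc1OC`. In this assay compound 2 gives > 10000 nM, again only a limit and not a number.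

Within the data shown here, compound 1 thus stands at the edge of what this assay reports, and so does compound 2: both values sit at the same limit (the limit of > 10000 nM in this assay, at which 2 of the 2 values shown sit), so no order between them can be read, and no step between measured compounds is available in this assay.

Compound 3 `COc1cc2nc(OC3CCN(C(=O)OC(C)(C)C)CC3)nc(Nc3ccc(S(C)(=O)=O)cc3)c2cc1OC` is the next compound to be measured in this assay. Against compound 1 the change is hydrogen in place of fluoro on an aromatic carbon. The fluoro sits ortho to a large group and meta to a methylsulfonyl group; what enters is hydrogen only.

Among the measured compounds shown here, since compound 1 itself shows no measurable response and compound 2, with a different substituent at the shared core, also sits at the limit, there is no measured step on which a gain could be founded. The step from compound 1 to compound 3 is expected to be a step that the limit leaves unreadable from compound 1 to compound 3, that is, nothing beyond the scatter. Compound 3 is therefore estimated at 12000 nM, with a range from 4000 nM to 40000 nM, and most likely the assay will again report only a limit.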

Compound 3, half-maximal effective concentration: > 10000 nM
Compound 3: a limit, no number; the forecaster's own chance of this, stated with the estimate: 85%; the middle value lies beyond the limit too.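

In this assay compound 3 gives > 10000 nM, which is a limit of the assay and not a number. No step from compound 1 to compound 3 can be read, because both compounds sit at the same limit: the limit of > 10000 nM in this assay, at which 3 of the 3 values shown sit.

The compounds shown leave open which change on the shared core, if any, would give a measurable response in this assay.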